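Compound 2 to compound 4: adding hydroxy

The source may report more compounds than this note shows. Statements on the series, on what has been measured and on what is new or still open speak of the compounds shown alone.

Measured in a functional assay on HCT-116 cells (Homo sapiens) for inhibition, read by MTT assay, with a stated time of 48 h; a lower number here means a stronger inhibitor, a higher number a weaker inhibitor:
- compound 1 `COc1cc(-c2nccn3cc(-c4ccc(Cl)cc4)nc23)cc(OC)c1OC` gives 351 nM
- compound 2 `COc1cc(-c2nccn3cc(-c4ccccc4)nc23)cc(OC)c1OC` gives 266 nM
- compound 3 `COc1cc(-c2nccn3cc(-c4ccc(C(F)(F)F)cc4)nc23)cc(OC)c1OC` gives > 10000 nM (a limit)

Within the data shown here, compound 2 (266 nM) and compound 1 (351 nM) hold the only two numbers, and they lie within the scatter of each other. The value of compound 3 is only a limit (> 10000 nM).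

Compound 4 `COc1cc(-c2nccn3cc(-c4ccc(O)cc4)nc23)cc(OC)c1OC` differs from compound 2 by hydroxy in place of hydrogen on an aromatic carbon and is thus the phenyl to 4-hydroxyphenyl change. Among the measured compounds shown here, no measured compound carries hydroxy, so the evidence is indirect. The measured steps at this place point in two ways. Chloro and hydrogen are not separated by a 1.3-fold lower number from compound 1 to compound 2 (0.12 log units; within the scatter) and the trifluoromethyl compound falls away sharply in both an at least 28-fold higher number from compound 1 to compound 3 (1.45 log units; beyond the scatter) and an at least 37-fold higher number from compound 2 to compound 3 (1.57 log units; beyond the scatter). A single substituent at this place can therefore be either neutral or costly, and the chloro compound and the trifluoromethyl compound go against any one rule.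

In this assay the estimated result is a 1.7-fold higher number from compound 2 to compound 4 (0.23 log units; within the scatter) and this expected step is a modest one toward a higher number, with a long upper tail. For compound 4 the expected value is 450 nM (estimated range 130 nM to 3000 nM).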

Compound 4, half-maximal inhibitory concentration: 901 nM
The estimate for compound 4 lay 2.0-fold (0.30 log units) below the measured number; low and high end bracket the measured number.
By their numbers in this assay, from the lowest: compounds 2 and 1 (each within the scatter of the next); then compound 4. At a limit, above all of these: compound 3.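

In this assay, hydroxy in place of hydrogen is a substituent at this place that separates from both hydrogen and chloro, which stayed within the scatter of each other: a 3.4-fold higher number from compound 2 to compound 4 (0.53 log units; beyond the scatter) and a 2.6-fold higher number from compound 1 to compound 4 (0.41 log units; beyond the scatter), both modest steps. The 4-hydroxyphenyl compound nevertheless keeps a measured number and stands well clear of the trifluoromethyl compound, an at least 11-fold lower number from compound 3 to compound 4 (1.04 log units; beyond the scatter), so substituents at this place now fall into three levels: hydrogen and chloro together, then hydroxy, then trifluoromethyl. Compound 3 holds a limit and not a number, so its step to compound 4 is a bound only: the limit of > 10000 nM in this assay, at which 1 of the 4 values shown sits.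

The compounds shown cannot tell whether the modest step belongs to hydroxy alone or would also appear with a methoxy, an amine or a carboxylic acid at the same place. They also leave open whether hydroxy on another carbon of this ring would give the same step, and whether any substituent here gives a lower number than the unsubstituted phenyl of compound 2.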